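Swapping a sulfur-containing side chain for a plain hexyl chain

The source may report more compounds than this note shows. Statements on the series, on what has been measured and on what is new or still open speak of the compounds shown alone.

Of the compounds shown here, three share one core and have been tested in a functional assay on ileum for inhibition of histamine H1 receptor (Cavia porcellus); on this read-out higher numbers stand for weaker inhibition and lower numbers for stronger inhibition. Compound 1, `CCCN1CCCN(c2nc3ccccc3n2CCOCC)CC1`, gives 8.4 nM in this assay. Compound 3, `CN1CCCN(c2nc3ccccc3n2CCOc2ccccc2)CC1`, gives 9.1 nM. Compound 2, `CCSCCn1c(N2CCN(C)CC2)nc2ccccc21`, gives 19 nM, the highest of the three numbers, meaning the weakest inhibition among them. Its nearest neighbour on this scale is compound 3, and the gap between them is beyond the usual scatter; the gap to compound 1 is wider still and also beyond the scatter.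

The unmeasured compound 4, `CCCCCCn1c(N2CCN(C)CC2)nc2ccccc21`, differs from compound 2 in a single spot on the side chain attached to the core: butyl in place of ethylsulfanyl on a saturated chain carbon, two bonds along the chain from an aromatic nitrogen. Read across the whole side chain, this turns a 2-(ethylsulfanyl)ethyl group into a hexyl group, so the chain keeps roughly its length but loses its sulfur and its one hydrogen-bond acceptor.

For the measured compounds named here, no measured pair here isolates this particular swap, so nothing in the data fixes its effect. The change is expected to leave compound 4 close to compound 2 in this assay, with at most a small step and no clear direction beyond the scatter; the expected step is a 1.2-fold lower number from compound 2 to compound 4 (0.07 log units; within the scatter). Compound 4 is therefore estimated at 16 nM, with a plausible range from 6 nM to 45 nM.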

Compound 4, half-maximal inhibitory concentration: 26 nM
Estimate against measurement, compound 4: 1.6-fold (0.21 log units) below, and the stated range covers the measured number.
By their numbers in this assay, from the lowest: compounds 1 and 3 (each within the scatter of the next); then compounds 2 and 4 (each within the scatter of the next).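

For the compounds shown here, compound 4 gives the first direct reading of this change: with butyl in place of ethylsulfanyl on a saturated chain carbon, two bonds along the chain from an aromatic nitrogen, this assay shows a 1.4-fold higher number from compound 2 to compound 4 (0.14 log units; within the scatter), so the two compounds cannot be told apart on this read-out. At this place, then, the sulfur and the one hydrogen-bond acceptor of the ethylsulfanyl group can both be lost without a step that stands out from the scatter, and a hexyl chain of plain carbon serves as well as the 2-(ethylsulfanyl)ethyl chain, at least in this single pair.

As far as these compounds go, whether the same holds for a chain ending in an amine or a carboxylic acid, or for a chain longer than hexyl, stays open, and compound 1 and compound 3 differ from this pair in more than one place, so they cannot settle it. Nothing on hand explains why this swap leaves the read-out within the scatter.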